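Swapping the Aryl Ether for an Isopropyl Ether

This account rests on a few compounds, and the source may have more. Where it says the series, first, only, none or still open, it means among the compounds named here.

Three measured compounds share one core and differ only in the group carried on the oxygen attached to the aromatic ring. Compound 1 `COc1ccccc1Oc1cncc(C2=CC3CNCC(C2)C3)c1` carries a 2-methoxyphenyl there, and in an in vitro assay on SH-SY5Y cells for displacement of a labelled ligand from Neuronal acetylcholine receptor; alpha3/beta4 (Homo sapiens) (on this read-out higher numbers stand for weaker inhibition and lower numbers for stronger inhibition), compound 1 gives 56 nM. Compound 2 `C1=C(c2cncc(Oc3ccccc3)c2)CC2CNCC1C2` carries a plain phenyl, and in this assay compound 2 gives 1.9 nM. Compound 3 `Clc1cccc(Oc2cncc(C3=CC4CNCC(C3)C4)c2)c1` carries a 3-chlorophenyl, and in this assay compound 3 gives 22 nM. Compound 3 thus stands second highest of the three numbers: a 2.5-fold lower number from compound 1 to compound 3 (0.41 log units; beyond the scatter), while a 12-fold higher number from compound 2 to compound 3 (1.06 log units; beyond the scatter).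

Compound 4 `CC(C)Oc1cncc(C2=CC3CNCC(C2)C3)c1` is the next step from compound 3: isopropyl in place of 3-chlorophenyl on an oxygen on an aromatic ring. Going by the values given here, none of the measured steps removes the ring altogether; they only change what sits on the phenyl, and such changes moved the number strongly, as in a 29-fold lower number from compound 1 to compound 2 (1.47 log units; beyond the scatter) and a 12-fold higher number from compound 2 to compound 3 (1.06 log units; beyond the scatter). Those steps therefore show that this region is sensitive, but give no direct guide to direction. For compound 4 in this assay a number near the middle of the spread of the three measured compounds is expected, estimated at 30 nM, with an expected range from 3 nM to 300 nM. That estimate amounts to an expected step of a 1.4-fold higher number from compound 3 to compound 4 (0.13 log units; within the scatter), not clearly beyond the scatter in either direction.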

Compound 4, inhibition constant: 4.8 nM
Beside the measured number, compound 4's estimate is 6.3-fold (0.80 log units) above it; the range from low to high includes it.
By their numbers in this assay, from the lowest: compound 2; then compound 4; then compound 3; then compound 1.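

The aromatic ring on this oxygen is not required for a low number in this assay: isopropyl, which has no ring and only 3 heavy atoms, gives a 4.6-fold lower number from compound 3 to compound 4 (0.66 log units; beyond the scatter) and a 12-fold lower number from compound 1 to compound 4 (1.07 log units; beyond the scatter). Isopropyl therefore outperforms both substituted phenyl groups, a comparison that the earlier compounds, all of which kept the ring, could not make, but it does not match the plain phenyl, with a 2.5-fold higher number from compound 2 to compound 4 (0.40 log units; beyond the scatter), so compound 2 still has the lowest number of the four. Among these compounds, then, a ring-free group falls between the plain phenyl and the two substituted phenyls, and no measurement is available to explain this order.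

With only one ring-free group in hand, the compounds shown cannot separate the effect of losing the ring from the effect of the branched shape of isopropyl, which a straight propyl chain or a cyclopropyl group on the same oxygen could help to address. They also leave open how far this tolerance extends, for example to a longer chain ending in an amine or a carboxylic acid.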